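A Methoxy Swap at the Assay Limit

The compounds below may be only part of what the source reports. "The series", "measured", "known", "first", "only" and "open" are said of these compounds alone.

In an ADME assay on HepG2 cells (Homo sapiens) for cytotoxicity, read by MTT assay, with a stated time of 48 h (a lower number here means a stronger inhibitor, a higher number a weaker inhibitor), compound 1 (`O=S(=O)(c1cccc(-c2ccc3ncnc(Nc4ccc(OCc5cccc(F)c5)c(Cl)c4)c3c2)c1)N1CCOCC1`) gives > 15000 nM as a limit. Compound 2 (`Cc1ccc(Nc2ncnc3ccc(-c4ccc(S(=O)(=O)N5CCOCC5)cc4)cc23)cc1`) gives > 15000 nM as a limit too. Compound 3 (`O=S(=O)(c1ccc(-c2ccc3ncnc(Nc4ccc(OCc5cccc(Br)c5)c(Cl)c4)c3c2)cc1)N1CCOCC1`) gives > 15000 nM as a limit as well, so it has no exact number of its own. Compound 3 therefore stands with the other two (the limit of > 15000 nM in this assay, at which 3 of the 3 values shown sit). Compound 4 (`COc1cccc(COc2ccc(Nc3ncnc4ccc(-c5ccc(S(=O)(=O)N6CCOCC6)cc5)cc34)cc2Cl)c1`) differs from compound 3 by methoxy in place of bromo on an aromatic carbon, meta to a large group (methoxy in place of bromo on an aromatic carbon). Going by the values given here, no measured step is available as a guide, so the estimated shift in this assay is small and without clear direction (a step that the limit leaves unreadable from compound 3 to compound 4), staying within the scatter. Compound 4 is expected to read 20000 nM in a range from 10000 nM to 40000 nM and may well return only a limit again.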

Compound 4, half-maximal inhibitory concentration: > 15000 nM
Compound 4: only a limit was reported (the forecaster's own chance of this, stated with the estimate: 80%); the middle value lies beyond the limit too.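

Going by these compounds alone, compound 3 and compound 4 both return only a limit in this assay, so no step between them can be read: the limit of > 15000 nM in this assay, at which 4 of the 4 values shown sit.

As far as these compounds go, what methoxy in place of bromo does in this assay remains open, as does where an exact reading would fall for any of the four compounds.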